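The source may report more compounds than this note shows. Statements on the series, on what has been measured and on what is new or still open speak of the compounds shown alone.

Compounds measured in a functional assay on A549 cells (Homo sapiens) for antiproliferative activity, read by MTT assay, with a stated time of 72 h; on this read-out higher numbers stand for weaker inhibition and lower numbers for stronger inhibition:
compound 1, `CCC(=O)Oc1ccc(C(=O)C2=C3OC(C)(C)[C@@H](CC=C(C)C)C[C@@]34C[C@@H](CC=C(C)C)C(C)(C)[C@H]3CCC(C)(C)O[C@]34OC2=O)cc1OC(=O)CC`, gives > 20000 nM
compound 2, `CCCCCC(=O)Oc1ccc(C(=O)C2=C3OC(C)(C)[C@@H](CC=C(C)C)C[C@@]34C[C@@H](CC=C(C)C)C(C)(C)[C@H]3CCC(C)(C)O[C@]34OC2=O)cc1OC(=O)CCCCC`, gives 19200 nM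
compound 3, `CC(C)=CC[C@H]1C[C@]23C[C@@H](CC=C(C)C)C(C)(C)[C@H]4CCC(C)(C)O[C@]42OC(=O)C(C(=O)c2ccc(OC(=O)c4ccc(F)cc4)c(OC(=O)c4ccc(F)cc4)c2)=C3OC1(C)C`, gives 11700 nM

All three carry the same core and differ only in the two esters on the aromatic ring. For compound 1 the entry of > 20000 nM is a limit of the assay, not a number, as the limit of > 20000 nM in this assay, at which 1 of the 3 values shown sits, records. Of the two numbers, compound 2 stands highest with 19200 nM, while compound 3 at 11700 nM sits within the scatter of it, so the two cannot be ordered. Among the measured compounds shown here, no pair of measured compounds differs in a single place, so no measured step tells how one ester change alone shifts the read-out.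

Compound 4, `CCCCCC(=O)Oc1cc(C(=O)C2=C3OC(C)(C)[C@@H](CC=C(C)C)C[C@@]34C[C@@H](CC=C(C)C)C(C)(C)[C@H]3CCC(C)(C)O[C@]34OC2=O)ccc1O`, is not yet measured. Set against compound 2 it shows (hydrogen in place of pentylcarbonyl on an oxygen on an aromatic ring). For the measured compounds named here, with compound 2 at 19200 nM as the anchor, and no measured single-place step to lean on, only a modest move is expected. In this assay the expected step is a 1.6-fold lower number from compound 2 to compound 4 (0.20 log units; within the scatter), toward a somewhat lower number, not confidently beyond the scatter. Compound 4 is therefore estimated at 12000 nM, with a range from 4000 nM to 30000 nM.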

Compound 4, half-maximal inhibitory concentration: 19500 nM
Estimate against measurement, compound 4: 1.6-fold (0.21 log units) below; the measured number falls inside the stated range.
By their numbers in this assay, from the lowest: compounds 3, 2 and 4 (each within the scatter of the next). At a limit, above all of these: compound 1.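

Taking away one pentylcarbonyl, so that hydroxy stands in place of (pentylcarbonyl)oxy on the aromatic ring, gives the first single-place step in this assay: a 1.0-fold higher number from compound 2 to compound 4 (0.01 log units; within the scatter). At this position, then, this assay does not tell the ester from the free hydroxy, something the three earlier compounds could not show, since no two of them differ in one place only. Compound 1 stands at a limit and not a number, and the read-out of this flat step lies close under that limit, so the step may say little about the change itself: the limit of > 20000 nM in this assay, at which 1 of the 4 values shown sits.

The compounds shown leave open whether a different group on this oxygen, such as an acyl chain carrying an amine or a carboxylic acid, or a chain longer than pentylcarbonyl, would move the number beyond the scatter. They also leave open whether the same exchange at the other ester on the ring would read the same, and what a ring with hydroxy in place of both esters would give.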